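A few compounds are considered here, and "the series" means these few. Any claim that something is new, unique, unknown or untested is made for them only; others in the source may bear on it.

Measured compounds:
compound 1, `COc1ncnc2c1c(I)cn2[C@@H]1O[C@H](CO)[C@@H](O)[C@H]1O`, in an ADME assay on MRC5 cells (Homo sapiens), read by MTT assay, with a stated time of 72 h (a higher number here means a weaker inhibitor, a lower number a stronger inhibitor), compound 1 gives 63000 nM.
compound 2, `C#Cc1cn([C@@H]2O[C@H](CO)[C@@H](O)[C@H]2O)c2ncnc(OC)c12`, in this assay compound 2 reaches only a limit, > 100000 nM.
compound 3, `COc1ncnc2c1c(-c1cc3ccccc3o1)cn2[C@@H]1O[C@H](CO)[C@@H](O)[C@H]1O`, in this assay compound 3 gives 65600 nM.

Compound 3 stands highest of the two numbers; the nearest is compound 1, with a 1.0-fold higher number from compound 1 to compound 3 (0.02 log units; within the scatter). The value of compound 2 is a limit of this assay, (the limit of > 100000 nM in this assay, at which 1 of the 3 values shown sits), not a number.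

Compound 4, `COc1ncnc2c1c(-c1ccoc1)cn2[C@@H]1O[C@H](CO)[C@@H](O)[C@H]1O`, differs from compound 3 in one place: furan-3-yl in place of 1-benzofuran-2-yl on an aromatic carbon. Among the measured compounds shown here, no measured step swaps these two groups directly, so the related steps must serve. At the same aromatic carbon, iodo to 1-benzofuran-2-yl gave a 1.0-fold higher number from compound 1 to compound 3 (0.02 log units; within the scatter), ethynyl to 1-benzofuran-2-yl gave an at least 1.5-fold lower number from compound 2 to compound 3 (0.18 log units; that floor lies within the scatter), and iodo to ethynyl gave an at least 1.5-fold higher number from compound 1 to compound 2 (0.20 log units; that floor lies within the scatter). Every substituent tried at this position has therefore yielded a number within the scatter of the others or a limit, and exchanging 1-benzofuran-2-yl for furan-3-yl is expected to follow that pattern with no step beyond the scatter in either direction.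

Compound 4 is therefore expected to give 65000 nM, between 30000 nM and 150000 nM. That expectation amounts to a 1.0-fold lower number from compound 3 to compound 4 (0.00 log units; within the scatter).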

Compound 4, half-maximal inhibitory concentration: 29400 nM
Estimate against measurement, compound 4: 2.2-fold (0.34 log units) above, outside the stated range (below it).
By their numbers in this assay, from the lowest: compound 4; then compounds 1 and 3 (each within the scatter of the next). At a limit, above all of these: compound 2.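

Among compound 1, compound 2 and compound 3, no step at this aromatic carbon lay beyond the scatter in this assay, but furan-3-yl moves the number beyond it, with a 2.2-fold lower number from compound 3 to compound 4 (0.35 log units; beyond the scatter) against 1-benzofuran-2-yl and a 2.1-fold lower number from compound 1 to compound 4 (0.33 log units; beyond the scatter) against iodo. Against ethynyl the step is an at least 3.4-fold lower number from compound 2 to compound 4 (0.53 log units; beyond the scatter), which is only a floor, as compound 2 stands at a limit and not at a number: the limit of > 100000 nM in this assay, at which 1 of the 4 values shown sits. Compound 4 therefore has the lowest number of the four, while compound 1 and compound 3 stay within the scatter of each other, so the position does respond to the group it carries, and among these groups only furan-3-yl separates from the rest.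

From the compounds shown here alone, it remains open whether this lower number belongs to the furan ring itself or to the way it is attached, which a furan-2-yl or a thiophen-3-yl group at the same carbon could test. Also open, going by these compounds, is whether an amine or a carboxylic acid on the furan ring would carry the number further in either direction.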